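Halophenyl swap on the amide nitrogen of the shared core

The compounds below may be only part of what the source reports. "The series", "measured", "known", "first", "only" and "open" are said of these compounds alone.

Compound 1 `O=C(CSc1nc2cccnc2[nH]1)Nc1cccc(Br)c1` is the lower of the two measured entries in an assay on isolated protein for inhibition of Ectonucleotide pyrophosphatase/phosphodiesterase family member 1 (Homo sapiens), tested at 10 uM (a higher number here means more inhibition at the concentration tested (going by the name of the read-out), a lower number less inhibition), where compound 1 gives 23%. Compound 2 `COc1ccc(NS(=O)(=O)CSc2nc3ncccc3[nH]2)cc1OC` stands higher: in this assay compound 2 gives 50%, a gap beyond the usual scatter. Compound 3 `O=C(CSc1nc2cccnc2[nH]1)Nc1ccc(Cl)cc1` is not yet measured; it differs from compound 1 by 4-chlorophenyl in place of 3-bromophenyl on an amide-type nitrogen. Among the compounds with values here, no measured pair shows such a change, so the expected step is small and within the scatter, estimated as a number 2 percentage points higher from compound 1 to compound 3 (within the scatter). For compound 3 the expected value in this assay is 25%, ranging from 5% to 45%.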

Compound 3, a percentage reported as inhibition, at one concentration (the size of the read-out at that concentration, not a potency): 17%
Beside the measured number, compound 3's estimate is 8 percentage points above it; the range from low to high includes it.
By their numbers in this assay, from the lowest: compounds 3 and 1 (each within the scatter of the next); then compound 2.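

Within the data shown here, the swap of 3-bromophenyl for 4-chlorophenyl on the amide-type nitrogen gives a number 6 percentage points lower from compound 1 to compound 3 (within the scatter) in this assay and is the first measured step at this position. This single change therefore does not separate the two halophenyl groups in this read-out. No supporting data bear on this result.

From the compounds shown here alone, the two groups differ in both the halogen and its place on the ring, and the share of each remains open. Also open, going by these compounds, is whether an amine, a carboxylic acid or a longer chain on this nitrogen would give a step beyond the scatter.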